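Adding methoxy groups to the benzoate of compound 1

This account rests on a few compounds, and the source may have more. Where it says the series, first, only, none or still open, it means among the compounds named here.

Compound 1, `COC(=O)/C(=C\c1ccc(OC(=O)c2ccccc2)cc1)Sc1ccnc2cc(Cl)ccc12`, was tested in an ADME assay on cells (Lymphocyte, Homo sapiens) for cytotoxicity, read by MTT assay, with a stated time of 48 h; a higher number here means a weaker inhibitor, a lower number a stronger inhibitor. In that test compound 1 gives only a limit of the assay, > 100000 nM, so its number is not pinned down; the relevant point is the limit of > 100000 nM in this assay, at which 1 of the 3 values shown sits. Two relatives put a number on the same core. Compound 2, `COC(=O)/C(=C\c1ccc(OC(=O)c2ccc(OC)cc2)cc1)Sc1ccnc2cc(Cl)ccc12`, gives 63500 nM in this assay. Compound 3, `COC(=O)/C(=C\c1ccc(OC(=O)c2cc(OC)c(OC)c(OC)c2)cc1)Sc1ccnc2cc(Cl)ccc12`, gives 35200 nM in this assay. The step of an at least 1.5-fold lower number from compound 1 to compound 2 (0.19 log units; that floor lies within the scatter) and the step of an at least 2.8-fold lower number from compound 1 to compound 3 (0.45 log units; beyond the scatter) both run toward lower numbers as methoxy groups enter the ring on the carbonyl carbon, while the step of a 1.8-fold lower number from compound 2 to compound 3 (0.26 log units; within the scatter) stays within the scatter, so the two methoxylated compounds cannot be ranked against each other.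

Compound 4, `COC(=O)/C(=C\c1ccc(OC(=O)c2ccc(OC)c(OC)c2OC)cc1)Sc1ccnc2cc(Cl)ccc12`, has not yet been measured. It differs from compound 1 by 2,3,4-trimethoxyphenyl in place of phenyl on a carbonyl carbon. This change resembles the change from compound 1 to compound 3, which also swapped a trimethoxyphenyl in for phenyl at the same carbonyl carbon, so a lowering of about the same size is expected rather than none, though compound 4 could still land at the limit. The estimate for compound 4 is 40000 nM, within 18000 nM to 100000 nM. That estimate means an expected step of an at least 2.5-fold lower number from compound 1 to compound 4 (0.39 log units; beyond the scatter).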

Compound 4, half-maximal inhibitory concentration: 22400 nM
Compound 4: the middle estimate sits 1.8-fold (0.25 log units) above what was measured; measured number inside the range.
By their numbers in this assay, from the lowest: compounds 4, 3 and 2 (each within the scatter of the next, the first and the last beyond it). At a limit, above all of these: compound 1.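

In this assay there is a 2.8-fold lower number from compound 2 to compound 4 (0.45 log units; beyond the scatter), so a trimethoxyphenyl group on this carbonyl carbon now stands apart from 4-methoxyphenyl by more than the scatter, which compound 3 did not achieve against the same partner. Placing the three methoxy groups as in 2,3,4-trimethoxyphenyl rather than 3,4,5-trimethoxyphenyl gives a 1.6-fold lower number from compound 3 to compound 4 (0.20 log units; within the scatter), so these two compounds cannot be ranked and the shift in methoxy placement shows no clear effect on the number. The full change from phenyl adds a second trimethoxyphenyl example, with an at least 4.4-fold lower number from compound 1 to compound 4 (0.64 log units; beyond the scatter), and the size of that step is only a floor because the starting compound gives no exact number: the limit of > 100000 nM in this assay, at which 1 of the 4 values shown sits.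

The compounds shown leave open whether the lower numbers depend on methoxy itself or whether an amine, a carboxylic acid or a longer chain such as ethoxy on the same ring would do the same. They also leave open whether the oxygen next to the carbonyl group matters, as an amine nitrogen in its place would test.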